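The source may hold more compounds than are shown below. What is called first, only, known or untested is meant among the compounds shown, and "the series" means these compounds.

In an assay on isolated protein for inhibition of serine/threonine-protein kinase TNNI3K (Homo sapiens) (a higher number here means a weaker inhibitor, a lower number a stronger inhibitor), compound 1 `CCCNc1cc(Oc2ccc(NC(=O)Nc3cccc(C(F)(F)F)c3)cc2)ncn1` gives 32 nM, and compound 2 `C[C@@H](O)CNc1cc(Oc2ccc(NC(=O)Nc3cccc(C(F)(F)F)c3)cc2)ncn1` gives 63 nM. Within the data shown here, these are the only two numbers available, and the step of a 2.0-fold higher number from compound 1 to compound 2 (0.29 log units; within the scatter) shows that the two values lie within the usual scatter of each other, so compound 2 cannot be told apart from compound 1 on potency. Compound 3 `CN(C)c1cc(Oc2ccc(NC(=O)Nc3cccc(C(F)(F)F)c3)cc2)ncn1` differs from compound 2 by dimethylamino in place of (2-hydroxypropyl)amino on an aromatic carbon. Among the measured compounds shown here, the only measured step that touches this region is a 2.0-fold higher number from compound 1 to compound 2 (0.29 log units; within the scatter), and it concerns the hydroxy group alone. For the measured compounds named here, no measured pair shows what happens when the whole (2-hydroxypropyl)amino group is replaced by dimethylamino, which also removes both hydrogen-bond donors. For compound 3 the step of a 1.3-fold higher number from compound 2 to compound 3 (0.10 log units; within the scatter) is therefore expected to be small, with wide uncertainty. In this assay compound 3 is estimated to give 80 nM, with a range from 25 nM to 260 nM.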

Compound 3, half-maximal inhibitory concentration: 2500 nM
The estimate for compound 3 lay 31-fold (1.49 log units) below the measured number, outside the stated range (above it).
By their numbers in this assay, from the lowest: compounds 1 and 2 (each within the scatter of the next); then compound 3.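

In this assay, replacing (2-hydroxypropyl)amino with dimethylamino on the aromatic carbon next to the ring nitrogen gives a 40-fold higher number from compound 2 to compound 3 (1.60 log units; beyond the scatter), and replacing propylamino with dimethylamino gives a 78-fold higher number from compound 1 to compound 3 (1.89 log units; beyond the scatter). The earlier pair, which differed only by a hydroxy group, stayed within the scatter, whereas these steps show that potency is sensitive to a larger change to the group at this position, although this swap alters several things at once: heavy atoms go from 5 to 3 and hydrogen-bond donors from 2 to 0. No supporting measurement is available to explain the loss. Methylamino, which keeps one methyl group on the nitrogen, would help show whether the loss follows from the second methyl group or from the shorter chain. From the compounds shown here alone, how a longer chain such as butylamino or a ring amine such as morpholine would behave at this position also remains open.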